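Pro-X carboxypeptidase series: tetrazolyl piperidine to oxadiazolyl-pyrimidinyl

The source may hold more compounds than are shown below. What is called first, only, known or untested is meant among the compounds shown, and "the series" means these compounds.

Measured compounds:
- compound 1 `O=C(CCN1CCC(c2ccccc2)CC1)N1CCC[C@H]1c1nc2cc(Cl)c(Cl)cc2[nH]1`: > 10000 nM (a limit)
- compound 2 `O=C(CCN1CCN(c2ccccc2)CC1)N1CCC[C@H]1c1nc2cc(Cl)c(Cl)cc2[nH]1`: > 10000 nM (a limit)
- compound 3 `O=C(CCN1CCC(n2ncnn2)CC1)N1CCC[C@H]1c1nc2cc(Cl)c(Cl)cc2[nH]1`: 2900 nM

Three compounds have been run in an assay on a cell-free system (plasma) for inhibition of lysosomal Pro-X carboxypeptidase (Mus musculus); a lower number here means a stronger inhibitor, a higher number a weaker inhibitor. Compound 1 reaches only the limit of > 10000 nM in this assay. Compound 2 likewise reaches only the limit of > 10000 nM. Going by the values given here, compound 3 is therefore the only compound of the three with a number in this assay, at 2900 nM; the other two stand at the limit of > 10000 nM in this assay, at which 2 of the 3 values shown sit.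

Among the compounds with values here, one measured step touches the same position. Going an at least 3.4-fold lower number from compound 1 to compound 3 (0.53 log units; beyond the scatter), the 2H-tetrazol-2-yl on the saturated ring carbon gave the only numeric value of the set.

Compound 4 `O=C(CCN1CCC(c2nc(-c3ncccn3)no2)CC1)N1CCC[C@H]1c1nc2cc(Cl)c(Cl)cc2[nH]1` continues at that position: a group of 11 heavy atoms (6 carbon, 4 nitrogen, 1 oxygen; one five-membered aromatic ring with 3 hetero atoms, one six-membered aromatic ring with 2 hetero atoms) in place of a group of 5 heavy atoms (1 carbon, 4 nitrogen; one five-membered aromatic ring with 4 hetero atoms), on a saturated ring carbon. The change enlarges the substituent from the tetrazole of compound 3 toward a two-ring aromatic group; the phenyl of compound 1 at this carbon sat at the limit, while the small heteroaromatic tetrazole of compound 3 gave a number. Within the data shown here, no measured step covers a biaryl heteroaromatic here, so the direction is open. The expectation for compound 4 in this assay is a value near that of compound 3, with the step of a 1.4-fold higher number from compound 3 to compound 4 (0.14 log units; within the scatter) within the scatter. Compound 4 is estimated at 4000 nM, between 1000 nM and 20000 nM, with a fair chance that only a limit is reported.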

Compound 4, half-maximal inhibitory concentration: 745 nM
Beside the measured number, compound 4's estimate is 5.4-fold (0.73 log units) above it; measured number outside the range, below it.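

In this assay, the saturated ring carbon accepts a much larger two-ring aromatic group, and the number improves rather than being lost: a 3.9-fold lower number from compound 3 to compound 4 (0.59 log units; beyond the scatter). Heavy atom count alone does not order this position, since the phenyl of compound 1 falls in size between the two groups that give numbers, yet compound 1 reaches only a limit and so goes against any simple trend with size. The gain over phenyl is an at least 13-fold lower number from compound 1 to compound 4 (1.12 log units; beyond the scatter), and it is a lower bound, as compound 1 has a limit rather than a number: the limit of > 10000 nM in this assay, at which 2 of the 4 values shown sit.

The compounds shown leave open whether the five-membered aromatic ring with 3 hetero atoms would account for the step without the six-membered ring, or whether a plain phenyl in place of that six-membered ring would keep it. Also open, from the compounds shown here alone, is how a carboxylic acid or a primary amine would read on this carbon, and whether the two-ring group would give a number on the piperazine ring of compound 2.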